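From Cyclopropyl to Pyridin-3-yl on the Amide Carbonyl

The source may hold more compounds than are shown below. What is called first, only, known or untested is meant among the compounds shown, and "the series" means these compounds.

Compound 2 `O=C(Nc1c(C(O)(C(F)(F)F)C(F)(F)F)ccc2ccccc12)C1CC1` gives 126 nM in a functional assay (Sus scrofa) with sulfonylurea receptors; K-ATP channels (Homo sapiens) as the target (on this read-out higher numbers stand for an effect only at larger amounts of compound and lower numbers for an effect already at smaller amounts), the lowest of the three numbers measured. Its nearest neighbour is compound 3 `O=C(Nc1c(C(O)(C(F)(F)F)C(F)(F)F)ccc2ccccc12)c1cccc([N+](=O)[O-])c1`, with 427 nM, and its furthest is compound 1 `CCCC(=O)Nc1c(C(O)(C(F)(F)F)C(F)(F)F)ccc2ccccc12`, with 708 nM; the measured steps are a 5.6-fold lower number from compound 1 to compound 2 (0.75 log units; beyond the scatter) and a 3.4-fold higher number from compound 2 to compound 3 (0.53 log units; beyond the scatter), while a 1.7-fold lower number from compound 1 to compound 3 (0.22 log units; within the scatter). Compound 4 `O=C(Nc1c(C(O)(C(F)(F)F)C(F)(F)F)ccc2ccccc12)c1cccnc1` differs from compound 2 in one place: pyridin-3-yl in place of cyclopropyl on a carbonyl carbon. Going by the values given here, the step that bears on it most is the one from compound 2 to compound 3, where another aromatic ring replaced cyclopropyl on the carbonyl carbon and the number rose modestly. A similar, modest rise is therefore expected for compound 4 in this assay, with a 2.5-fold higher number from compound 2 to compound 4 (0.40 log units; beyond the scatter). Compound 4 is estimated at 320 nM, within 120 nM to 850 nM.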

Compound 4, half-maximal effective concentration: 617 nM
For compound 4 the middle estimate is 1.9-fold (0.29 log units) below the measured one; the measured number falls inside the stated range.
By their numbers in this assay, from the lowest: compound 2; then compounds 3, 4 and 1 (each within the scatter of the next).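

In this assay, the higher number seen with 3-nitrophenyl on the carbonyl carbon also appears with a second aromatic ring, pyridin-3-yl, which leaves cyclopropyl alone in giving the lowest number (a 4.9-fold higher number from compound 2 to compound 4 (0.69 log units; beyond the scatter)). Pyridin-3-yl cannot be told apart from 3-nitrophenyl (a 1.4-fold higher number from compound 3 to compound 4 (0.16 log units; within the scatter)) or from propyl (a 1.1-fold lower number from compound 1 to compound 4 (0.06 log units; within the scatter)). No evidence at hand explains this result. The compounds shown leave open whether cyclobutyl would keep the low number of compound 2. They also leave open where unsubstituted phenyl would fall.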